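Expected Potency of Compound 4 After a Small Group Swap

The source may report more compounds than this note shows. Statements on the series, on what has been measured and on what is new or still open speak of the compounds shown alone.

Measured in a functional assay on MCF7 cells (Homo sapiens) for inhibition, read by MTT assay, with a stated time of 48 h; a higher number here means a weaker inhibitor, a lower number a stronger inhibitor:
- compound 1 `CCOC(=O)C1=C(NN=C(C(C)=O)C(C)=O)Nc2[nH]nc(C)c2C1c1ccc(N(C)C)cc1` gives 9740 nM
- compound 2 `CCOC(=O)C1=C(N/C=N/c2nnc(S(N)(=O)=O)s2)Nc2[nH]nc(C)c2C1c1ccc(N(C)C)cc1` gives 34500 nM
- compound 3 `CCOC(=O)C1=C(N/N=C(\C#N)C(N)=O)Nc2[nH]nc(C)c2C1c1ccc(N(C)C)cc1` gives 50100 nM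

Compound 3 cannot be told apart from compound 2, with a 1.5-fold higher number from compound 2 to compound 3 (0.16 log units; within the scatter). Both stand on the weaker side of compound 1, with a 5.1-fold higher number from compound 1 to compound 3 (0.71 log units; beyond the scatter) and a 3.5-fold higher number from compound 1 to compound 2 (0.55 log units; beyond the scatter).

Compound 4 `CCOC(=O)C1=C(NN=C(C#N)C#N)Nc2[nH]nc(C)c2C1c1ccc(N(C)C)cc1` differs from compound 3 by a group of 6 heavy atoms (3 carbon, 3 nitrogen; no ring) in place of a group of 7 heavy atoms (3 carbon, 3 nitrogen, 1 oxygen; no ring), on an amine nitrogen. Within the data shown here, no measured step covers this exact swap. The closest evidence is from larger changes on the same amine nitrogen, and even a 5.1-fold higher number from compound 1 to compound 3 (0.71 log units; beyond the scatter) stayed modest. A small move is therefore expected, and a 1.7-fold lower number from compound 3 to compound 4 (0.22 log units; within the scatter) is the estimated step, not expected to exceed the scatter. Compound 4 is expected near 30000 nM, within an estimated range of 10000 nM to 80000 nM.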

Compound 4, half-maximal inhibitory concentration: 12100 nM
Compound 4: the middle estimate sits 2.5-fold (0.39 log units) above what was measured; low and high end bracket the measured number.
By their numbers in this assay, from the lowest: compounds 1 and 4 (each within the scatter of the next); then compounds 2 and 3 (each within the scatter of the next).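

Even a small swap on this amine nitrogen can matter: a 4.1-fold lower number from compound 3 to compound 4 (0.62 log units; beyond the scatter), beyond the scatter, as the hydrogen-bond donor count of the group falls from 1 to 0. The new group also gives a 2.9-fold lower number from compound 2 to compound 4 (0.46 log units; beyond the scatter), whereas a 1.2-fold higher number from compound 1 to compound 4 (0.09 log units; within the scatter) lies within the scatter, so two quite different groups without a ring give indistinguishable numbers. No measured evidence accounts for these shifts. As far as these compounds go, whether the donor count matters on its own remains open, as does the effect of a carboxylic acid or a simple amine on this nitrogen.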